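The source may hold more compounds than are shown below. What is called first, only, known or untested is meant among the compounds shown, and "the series" means these compounds.

Measured compounds:
- compound 1 `CCC1(CCCCN2CCN(c3ccc(F)cc3)CC2)C(=O)Nc2ccccc21`: 10 mg/kg
- compound 2 `CCC1(CCCCN2CCN(c3ccc(Cl)cc3)CC2)C(=O)Nc2cc(F)c(Cl)cc21`: "not determined" (no result reported)

The study rests on a single number. Compound 1 `CCC1(CCCCN2CCN(c3ccc(F)cc3)CC2)C(=O)Nc2ccccc21` was tested in a functional assay on the whole organism (strain Wistar) with Rattus norvegicus as the target, with a stated time of 5 min (a lower number here means that less compound is needed, a higher number that more compound is needed for the effect), and gave 10 mg/kg. Compound 2 `CCC1(CCCCN2CCN(c3ccc(Cl)cc3)CC2)C(=O)Nc2cc(F)c(Cl)cc21` belongs to the same series, but in this assay compound 2 is recorded as "not determined" (no result reported), so no number is available for it and nothing can be said of how it compares with compound 1. Compound 1 therefore stands alone as the only reference point in this assay.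

The next compound, compound 3 `CCC1(CCCCN2CCN(c3ccccc3OC)CC2)C(=O)Nc2ccccc21`, has not been measured yet. It differs from compound 1 in one place: 2-methoxyphenyl in place of 4-fluorophenyl on an amine nitrogen in a ring. For the measured compounds named here, with no measured pair that shows how such a change plays out in this assay, there is no basis in the data for a step of any particular size or direction; a change within the scatter is the plainest expectation. Compound 3 is estimated at 8 mg/kg, with a range from 2 mg/kg to 30 mg/kg. This estimate means a step from a 1.3-fold lower number from compound 1 to compound 3 (0.10 log units; within the scatter) that is not expected to exceed the usual scatter.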

Compound 3, minimum effective dose: 10 mg/kg
Beside the measured number, compound 3's estimate is 1.3-fold (0.10 log units) below it, and the stated range covers the measured number.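

For the compounds shown here, this is the first pair that can be read in this assay: the result is no change at the digits printed from compound 1 to compound 3 (within the scatter) when 2-methoxyphenyl takes the place of 4-fluorophenyl on an amine nitrogen in a ring. The group on this nitrogen can therefore be exchanged, from one with 7 heavy atoms and 0 hydrogen-bond acceptors to one with 8 heavy atoms and 1 hydrogen-bond acceptor, without a step beyond the scatter. Nothing measured here bears on why the two compounds read alike.

A single pair at a single position cannot show whether other groups on this nitrogen, such as a benzyl group or a pyridine ring, would read the same way. This exchange also alters both the kind of substituent on the phenyl ring and where it sits, so the pair cannot separate the effect of fluorine giving way to methoxy from the shift between the 4-fluoro and 2-methoxy arrangements.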